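Series notes: replacing the piperidine arm of compound 1

A few compounds are considered here, and "the series" means these few. Any claim that something is new, unique, unknown or untested is made for them only; others in the source may bear on it.

Compound 1 `O=C1O[C@@H](CN2CCCCC2)CN1c1ccc(-n2cc(-c3ccccn3)cn2)c(F)c1` is the reference point. In a physicochemical assay for lipophilicity, read by HPLC, measured as octanol-water partition (on this read-out higher numbers stand for higher lipophilicity and lower numbers for lower lipophilicity), compound 1 gives 3.1, the second highest of the three numbers. Compound 2 `COC(=O)CC1CCN(C[C@H]2CN(c3ccc(-n4cc(-c5ccccn5)cn4)c(F)c3)C(=O)O2)CC1` gives 1.78 and compound 3 `O=C1O[C@@H](CN2CCC(c3ccc(F)cc3)CC2)CN1c1ccc(-n2cc(-c3ccccn3)cn2)c(F)c1` gives 5.78; the step of a number 1.32 log units lower from compound 1 to compound 2 (beyond the scatter) and the step of a number 2.68 log units higher from compound 1 to compound 3 (beyond the scatter) show how strongly substituents on the piperidine ring move this assay. Compound 4 `O=C1CSC(=O)N1C[C@H]1CN(c2ccc(-n3cc(-c4ccccn4)cn3)c(F)c2)C(=O)O1` differs from compound 1 as follows: 2,4-dioxo-1,3-thiazolidin-3-yl in place of piperidin-1-yl on a saturated chain carbon bound to a saturated ring carbon. Going by the values given here, no measured step covers the loss of the piperidine itself, so the steps to compound 2 and compound 3 only set the scale. The change is expected to lower this assay, with an expected step of a number 1.30 log units lower from compound 1 to compound 4 (beyond the scatter), so compound 4 is estimated at 1.8, between 1 and 2.6.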

Compound 4, partition coefficient: 2.18
The estimate for compound 4 lay 0.38 log units below the measured number, and the stated range covers the measured number.
By their numbers in this assay, from the lowest: compound 2; then compound 4; then compound 1; then compound 3.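

Exchanging the whole arm for 2,4-dioxo-1,3-thiazolidin-3-yl, rather than substituting on the piperidine ring, still moves this assay with a step of a number 0.92 log units lower from compound 1 to compound 4 (beyond the scatter) and leaves a step of a number 0.40 log units higher from compound 2 to compound 4 (beyond the scatter). The entering ring, with 3 hydrogen-bond acceptors, therefore does not reach the lowest number of the set, which stays with compound 2. No measurement shown explains either step.

Still open, on these data alone, is where a morpholin-4-yl arm, or a carboxylic acid in place of the methyl ester of compound 2, would fall on this scale.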